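Cyclopropylamino in place of piperidin-1-yl in compound 1

A few compounds are considered here, and "the series" means these few. Any claim that something is new, unique, unknown or untested is made for them only; others in the source may bear on it.

Measured so far in a functional assay on NCI-H1975 cells (Homo sapiens) for inhibition; on this read-out lower numbers stand for stronger inhibition of growth and higher numbers for weaker inhibition of growth 
- compound 1 `O=C(/C=C/CN1CCCCC1)Nc1cc2c(Nc3ccc(F)c(Cl)c3)ncnc2cc1O[C@H]1CCOC1` gives 168 nM 
- compound 2 `CCOc1cc2ncnc(Nc3ccc(F)c(Cl)c3)c2cc1NC(=O)/C=C/CN(C)C1CC1` gives 160 nM 

On these numbers, compound 1 at 168 nM sits level with compound 2 at 160 nM, and the two lie within the scatter of each other, so neither ranks ahead.

The next compound, compound 3 `O=C(/C=C/CNC1CC1)Nc1cc2c(Nc3ccc(F)c(Cl)c3)ncnc2cc1O[C@H]1CCOC1`, keeps the core of compound 1 and carries cyclopropylamino in place of piperidin-1-yl on a saturated chain carbon bound to a double-bonded chain carbon.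

For the measured compounds named here, the series holds no measured step between compounds that differ in one place, so this replacement has no direct precedent here. The expectation starts from compound 1 at 168 nM and has to stay wide. In this assay no shift beyond the scatter is expected, and two compounds give no basis for a direction. The estimated step is a 1.1-fold higher number from compound 1 to compound 3 (0.03 log units; within the scatter), which is expected to be no clear move either way. For compound 3 the expected value is 180 nM, with an estimated range from 60 nM to 550 nM.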

Compound 3, concentration for 50% growth inhibition: 10.2 nM
For compound 3 the middle estimate is 18-fold (1.25 log units) above the measured one, and the stated range ends above it.
By their numbers in this assay, from the lowest: compound 3; then compounds 2 and 1 (each within the scatter of the next).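

In this assay, for the compounds shown here, the saturated chain carbon bound to a double-bonded chain carbon proves highly sensitive to the group it carries: cyclopropylamino in place of piperidin-1-yl gives a 16-fold lower number from compound 1 to compound 3 (1.22 log units; beyond the scatter), the first reading from compounds that differ in one place. Compound 1 and compound 2 differ in more than one place, so their matching values said nothing about this position alone. The change alters several things at once, replacing a six-membered ring with a three-membered one, reducing the heavy atoms of the group from 6 to 4, and adding 1 hydrogen-bond donor, and no available evidence ties the step to any one of these differences.

Isopropylamino at this carbon would keep the donor without the three-membered ring, whereas azetidin-1-yl would keep a small ring without the donor, so this pair would help separate those two features. Compound 2 also carries a cyclopropyl group on its amine, but it differs from compound 3 in more than one place, which leaves the effect of a methyl group on the cyclopropylamino nitrogen unresolved.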